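Trimming the amino substituent on the shared core

The source may hold more compounds than are shown below. What is called first, only, known or untested is meant among the compounds shown, and "the series" means these compounds.

Compound 1 `CCCCNc1nc(C(F)(F)F)ccc1CNC(=O)C(C)c1ccc(NS(C)(=O)=O)c(F)c1`: 293 nM
Compound 2 `CC(C(=O)NCc1ccc(C(F)(F)F)nc1NCC1CCN(C(=O)OC(C)(C)C)CC1)c1ccc(NS(C)(=O)=O)c(F)c1`: 1140 nM
Compound 3 `Cc1ccc(Nc2nc(C(F)(F)F)ccc2CNC(=O)C(C)c2ccc(NS(C)(=O)=O)c(F)c2)cc1C`: 1160 nM

These three compounds were tested in a functional assay on CHO-K1 cells for antagonist activity at transient receptor potential cation channel subfamily V member 1 (Homo sapiens), read by FLIPR; on this read-out lower numbers stand for stronger inhibition and higher numbers for weaker inhibition. Compound 3 holds the highest number of the three; compound 2 sits within the scatter of it, while compound 1 sits a good deal lower. Going by the values given here, the one single-point step on record, a 4.0-fold higher number from compound 1 to compound 3 (0.60 log units; beyond the scatter), concerns the same nitrogen that is now changed, and it shows a modest rise when a larger aryl group replaced a small alkyl chain there.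

Compound 4 `CC(C(=O)NCc1ccc(C(F)(F)F)nc1N(C)C)c1ccc(NS(C)(=O)=O)c(F)c1` differs from compound 3 by dimethylamino in place of (3,4-dimethylphenyl)amino on an aromatic carbon. Among the compounds with values here, no measured step matches this change exactly: the aryl group is removed, and the hydrogen on that nitrogen is replaced by a methyl group at the same time, which none of the measured compounds does. The step from compound 1 to compound 3 suggests that a smaller group on this nitrogen goes with a lower number, so compound 4 is expected to show a 1.9-fold lower number from compound 3 to compound 4 (0.29 log units; within the scatter), a modest fall rather than a large one. Compound 4 is therefore estimated at 600 nM, with a range from 200 nM to 2500 nM.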

Compound 4, half-maximal inhibitory concentration: 2390 nM
Compound 4: middle estimate off by 4.0-fold (0.60 log units), on the low side; measured number inside the range.
By their numbers in this assay, from the lowest: compound 1; then compounds 2 and 3 (each within the scatter of the next); then compound 4.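

Making the group on this nitrogen smaller did not lower the number: dimethylamino gave a 2.1-fold higher number from compound 3 to compound 4 (0.31 log units; beyond the scatter) and, against butylamino, an 8.2-fold higher number from compound 1 to compound 4 (0.91 log units; beyond the scatter) in the same direction. Size alone therefore does not order this position, since butylamino goes with a lower number than (3,4-dimethylphenyl)amino, yet dimethylamino, the smaller group, goes with a higher number than both. Dimethylamino also differs from the other two groups in having no hydrogen on this nitrogen, so the change in compound 4 brings two differences at once.

The compounds shown leave open which of these differences matters, a question that methylamino, which keeps that hydrogen on a short chain, or a pyrrolidine ring, which lacks it, could help to separate. No available evidence explains the rise at this position.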